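Dichlorination of the styryl phenyl in a sulfonamide series

This account rests on a few compounds, and the source may have more. Where it says the series, first, only, none or still open, it means among the compounds named here.

Measured compounds:
Compound 1 `NCc1nnc(-c2cc(S(N)(=O)=O)c(SCc3ccccc3)cc2Cl)o1`: 135000 nM
Compound 2 `NS(=O)(=O)c1cc(-c2nnc(/C=C/c3ccccc3)o2)c(Cl)cc1SCc1ccccc1`: 16000 nM

Within the data shown here, in a functional assay on MCF7 cells (Homo sapiens) for cytotoxicity, read by MTT assay, with a stated time of 72 h (on this read-out higher numbers stand for weaker inhibition and lower numbers for stronger inhibition), compound 2 gives the lowest of the two numbers; the only measured step, an 8.4-fold lower number from compound 1 to compound 2 (0.93 log units; beyond the scatter), concerns a different position. Compound 3 `NS(=O)(=O)c1cc(-c2nnc(/C=C/c3c(Cl)cccc3Cl)o2)c(Cl)cc1SCc1ccccc1` differs from compound 2 by 2,6-dichlorophenyl in place of phenyl on a double-bonded chain carbon bound to a double-bonded chain carbon. Among the measured compounds shown here, no measured step touches this position, so the size of the change is unknown and no shift beyond the scatter is expected. Compound 3 is estimated at 12000 nM, within 4000 nM to 40000 nM, a step of a 1.3-fold lower number from compound 2 to compound 3 (0.12 log units; within the scatter).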

Compound 3, half-maximal inhibitory concentration: 29000 nM
The estimate for compound 3 lay 2.4-fold (0.38 log units) below the measured number; low and high end bracket the measured number.
By their numbers in this assay, from the lowest: compounds 2 and 3 (each within the scatter of the next); then compound 1.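

In this assay, 2,6-dichlorophenyl in place of phenyl gives a 1.8-fold higher number from compound 2 to compound 3 (0.26 log units; within the scatter), so compound 2 and compound 3 cannot be told apart here, and this position tolerates the two chlorine atoms without a clear shift. With the chlorines present, 2-(2,6-dichlorophenyl)ethenyl in place of aminomethyl still gives a 4.7-fold lower number from compound 1 to compound 3 (0.67 log units; beyond the scatter). Nothing available explains either result. As far as these compounds go, it remains open whether a methoxy group or an amine on this phenyl ring would separate clearly from compound 2, and in which direction.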